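The compounds below may be only part of what the source reports. "The series", "measured", "known", "first", "only" and "open" are said of these compounds alone.

Measured in a functional assay on HeLa cells (Homo sapiens) for inhibition, read by CCK-8 assay, with a stated time of 48 h; on this read-out higher numbers stand for weaker inhibition and lower numbers for stronger inhibition:

Compound 1 `COc1cc(-c2ccnc3cc(-c4cn(CO)c5ccccc45)nn23)cc(OC)c1OC` gives 103 nM.
Compound 2 `COc1cc(-c2cc3nccc(-c4c[nH]c5ccccc45)n3n2)cc(OC)c1OC` reaches only the limit of the assay, > 10000 nM.
Compound 3 `COc1cc(-c2ccnc3cc(-c4ccc(C)cc4)nn23)cc(OC)c1OC` gives 21 nM.

All three compounds share a core carrying three methoxy groups on one phenyl ring; they differ in the group attached on the other side of that core. Compound 3 has the lowest of the two measured numbers, and its gap to compound 1 lies beyond the scatter of repeated measurements. Compound 2 gives no number at all, only a limit, as noted in the limit of > 10000 nM in this assay, at which 1 of the 3 values shown sits.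

Compound 4 `COc1cc(-c2ccnc3cc(-c4cccc(C)c4)nn23)cc(OC)c1OC` is the next compound to be tested in this assay . Compared with compound 3 it carries 3-methylphenyl in place of 4-methylphenyl on an aromatic carbon; the two compounds are built from the same atoms, joined differently. Since the methyl group is merely moved on the same phenyl ring, the step of a 1.4-fold higher number from compound 3 to compound 4 (0.15 log units; within the scatter) is expected to stay within the usual scatter, with no clear direction. Compound 4 is therefore expected to give about 30 nM in this assay , with a plausible range from 10 nM to 90 nM.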

Compound 4, half-maximal inhibitory concentration: 4230 nM
Estimate against measurement, compound 4: 140-fold (2.15 log units) below; the measured number lies above the stated range.
By their numbers in this assay, from the lowest: compound 3; then compound 1; then compound 4. At a limit, above all of these: compound 2.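

In this assay, moving one methyl group on the same phenyl ring, with 3-methylphenyl in place of 4-methylphenyl, gives a 200-fold higher number from compound 3 to compound 4 (2.30 log units; beyond the scatter). No atom is gained or lost, and the counts of heavy atoms, hydrogen-bond donors and acceptors stay the same, so those counts cannot separate these two compounds. This is the first pair shown that differs in one place, and it shows that at this aromatic carbon of the five-membered ring, where the methyl group sits on the phenyl ring can matter a great deal.

Nothing measured here explains why this move has so large an effect. Going by these compounds, it also remains open whether a methoxy group, a chlorine atom or an amine in place of the methyl group would show the same sensitivity to its place on the phenyl ring.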